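Thymol-type core: carbamate versus meta-substituted benzoate esters

A few compounds are considered here, and "the series" means these few. Any claim that something is new, unique, unknown or untested is made for them only; others in the source may bear on it.

Measured so far in a functional assay on K562 cells (Homo sapiens) for antiproliferative activity, read by sulforhodamine B assay, with a stated time of 48 h, tested at 50 uM; a higher number here means more inhibition at the concentration tested (going by the name of the read-out), a lower number less inhibition:
- compound 1 `CC1=CC[C@H](C(C)C)c2cc(C)c(OC(=O)Nc3ccccc3)cc21`: 92.6%
- compound 2 `CC1=CC[C@H](C(C)C)c2cc(C)c(OC(=O)c3cccc(C)c3)cc21`: "not active" (no number reported)

Compound 1 carries a phenylcarbamate on the shared core and in this assay gives 92.6%. Compound 2 replaces the carbamate with a 3-methylbenzoate ester and in this assay is recorded as "not active" (no number reported), with no number attached. Compound 2 therefore stands without a single figure; all that can be said is that it falls clearly short of compound 1, whose inhibition is high.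

Compound 3 `CC1=CC[C@H](C(C)C)c2cc(C)c(OC(=O)c3cccc([N+](=O)[O-])c3)cc21` is the next ester to be tested. It differs from compound 2 in one place: nitro in place of methyl on an aromatic carbon. The ester linkage and the rest of the core are unchanged.

Within the data shown here, no measured step exists between two esters of this kind, so the size and direction of the change from compound 2 to compound 3 in this assay cannot be read from the data. Given that compound 2 shows "not active" (no number reported), the expectation is a small to moderate rise at best, possibly nothing beyond the scatter, with a real chance that compound 3 is again recorded without a number. For compound 3 the estimated inhibition in this assay is 25%, expected to lie between 0% and 65%.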

Compound 3, a percentage reported as inhibition, at one concentration (the size of the read-out at that concentration, not a potency): 15.9%
For compound 3 the middle estimate is 9.1 percentage points above the measured one; the range from low to high includes it.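

In this assay compound 3 gives 15.9%, so an ester of this type can return a number when 3-nitrophenyl replaces 3-methylphenyl, though that number remains low. The step from compound 2 to compound 3 cannot be read, as compound 2 has no number, and nothing can be said about the size of the nitro-for-methyl exchange. Replacing anilino with 3-nitrophenyl on the carbonyl carbon gives a number 76.7 percentage points lower from compound 1 to compound 3 (beyond the scatter) and puts a size on a gap that compound 2 could show only as a missing value; no measurement given here accounts for this gap or for the result with nitro.

Still open, on these data alone, is how the same aromatic carbon of the ester behaves with an amine or a carboxylic acid in place of nitro, and whether any such group lifts inhibition close to that of compound 1. Also open, as far as these compounds go, is whether a nitro group on the phenyl ring of the carbamate would keep the high inhibition of compound 1, which would show how far the linkage alone sets the outcome on the shared core.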